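The compounds below may be only part of what the source reports. "The series", "measured", "known", "first", "only" and "open" are said of these compounds alone.

Compound 1, `COc1ccc(-c2cc(/C=C/C(=O)c3ccc(N)cc3)[nH]n2)cc1`, gives -78% in a functional assay on KM12 cells (Homo sapiens) for cytotoxicity, read by sulforhodamine B assay, with a stated time of 48 h, tested at 100 uM; a lower number here means a stronger effect, a higher number a weaker effect of the compound at the concentration tested.
Compound 2, `COc1cc(-c2cc(/C=C/C(=O)c3ccc(N)cc3)[nH]n2)cc(OC)c1OC`, gives -79% in this assay.

On the numbers shown, compound 2 sits alongside compound 1 at the strong end of the read-out; the two numbers differ by an amount within the scatter, so nothing separates them. Going by the values given here, both share the same core, and the two measured points give no step that tells how a change at the carbonyl end behaves.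

Compound 3, `COc1cc(-c2cc(/C=C/C(=O)c3ccc(Cl)c(Cl)c3)[nH]n2)cc(OC)c1OC`, has not yet been measured. It differs from compound 2 in one place: 3,4-dichlorophenyl in place of 4-aminophenyl on a carbonyl carbon. The 4-aminophenyl on the carbonyl carbon leaves and 3,4-dichlorophenyl enters, the carbonyl carbon keeping its double-bonded chain carbon as the other neighbour.

Among the compounds with values here, with no measured step to lean on, the estimate rests on the level of compound 2 alone. Compound 3 is expected to give -68% in this assay, between -95% and -25%. The step expected from compound 2 to compound 3 is a number 11 percentage points higher from compound 2 to compound 3 (beyond the scatter), a modest move toward a weaker effect that may not clear the scatter.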

Compound 3, a percentage reported as activity, at one concentration (the size of the read-out at that concentration, not a potency): 3%
Compound 3: middle estimate off by 71 percentage points, on the low side, outside the stated range (above it).
By their numbers in this assay, from the lowest: compounds 2 and 1 (each within the scatter of the next); then compound 3.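

The group on the carbonyl carbon proves decisive for this read-out: putting 3,4-dichlorophenyl in place of 4-aminophenyl gives a number 82 percentage points higher from compound 2 to compound 3 (beyond the scatter) in this assay, so the strong effect seen with 4-aminophenyl does not survive this change. Compound 1 and compound 2 both carry 4-aminophenyl at this place, so neither could show how much the read-out depends on the group there. The change removes the hydrogen-bond donor and acceptor counted on the leaving group and brings in two chlorine atoms, but no measurement shown here explains why the read-out moves.

From the compounds shown here alone, it remains open whether the 4-aminophenyl group is needed for the strong effect or the 3,4-dichlorophenyl group itself weakens it, a question that an unsubstituted phenyl, a 4-hydroxyphenyl or a 4-chlorophenyl on the carbonyl carbon could help to settle. Going by these compounds, it is also open whether the same exchange would have a step of similar size on the core of compound 1, which differs from compound 2 at the other end of the molecule.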